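The source may report more compounds than this note shows. Statements on the series, on what has been measured and on what is new or still open speak of the compounds shown alone.

Compounds measured so far:
compound 1, `CCOCCCCc1cc(=O)c2cc([N+](=O)[O-])ccc2[nH]1`: 50000 nM
compound 2, `CCOCCCCc1[nH]c2ccc([N+](=O)[O-])cc2c(=O)c1C(=O)O`: 50000 nM
compound 3, `CCCCCCCc1[nH]c2ccncc2c(=O)c1C(=O)O`: 50000 nM

In a physicochemical assay for solubility, read by HPLC, at pH 7.4 (a higher number here means a more soluble compound, a lower number a less soluble compound), compound 1 gives 50000 nM, compound 2 gives 50000 nM and compound 3 gives 50000 nM, so the three sit at the same level within the scatter. Within the data shown here, the one step between measured neighbours is no change at the digits printed from compound 2 to compound 1 (within the scatter), made by the change (hydrogen in place of carboxy on an aromatic carbon). How the core of compound 3 differs from the core of compound 2 is not broken down here; the two are alike only in the ring atoms around the place of change.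

Compound 4, `CCCCCCCc1cc(=O)c2cnccc2[nH]1`, is not yet measured. It arises from compound 3 by hydrogen in place of carboxy on an aromatic carbon. Among the measured compounds shown here, this is the same kind of change as the one from compound 2 to compound 1, with the difference around the place that the changed carbon in compound 3 is ortho to a heptyl group, whereas in compound 2 it is ortho to a 4-ethoxybutyl group. Because no change at the digits printed from compound 2 to compound 1 (within the scatter), compound 4 is expected to sit level with compound 3, a step of no change at the digits printed from compound 3 to compound 4 (within the scatter). The estimate for compound 4 in this assay is 50000 nM, between 25000 nM and 100000 nM.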

Compound 4, solubility: 50000 nM
For compound 4 middle estimate and measured number coincide at the digits printed, within the range that was stated.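

In this assay the replacement of carboxy by hydrogen reads as no change at the digits printed from compound 3 to compound 4 (within the scatter) on the core carrying the heptyl group, and as no change at the digits printed from compound 2 to compound 1 (within the scatter) on the core carrying the 4-ethoxybutyl group. The change therefore carried from one core to the other with the same outcome, and neither pair goes against this, though two pairs are all that support it. This does not show that the same would hold on a third core or with another chain, and nothing here bears on why the two steps read alike.

As far as these compounds go, what stays open is whether the same replacement would read alike on a core carrying an amine, or on one with a chain longer than the heptyl group. The compounds shown also contain no step beyond the scatter, so they leave open which change in structure, if any, would move the reading in this assay.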